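Methylating a phenol in a macrocyclic carbamate series

The compounds below may be only part of what the source reports. "The series", "measured", "known", "first", "only" and "open" are said of these compounds alone.

Measured so far:
Compound 1 `CO[C@H]1C[C@H](C)Cc2cc(O)cc(c2)NC(=O)/C=C/CC[C@H](OC)[C@@H](OC(N)=O)/C(C)=C/[C@H](C)[C@H]1O`: > 10000 nM
Compound 2 `COc1c2cc(cc1OC(C)=O)NC(=O)/C(C)=C/CC[C@H](OC)[C@@H](OC(N)=O)/C(C)=C/[C@H](C)[C@@H](O)[C@@H](OC)C[C@H](C)C2`: 610 nM
Compound 3 `CO[C@H]1C[C@H](C)Cc2cc(cc(O)c2O)NC(=O)/C(C)=C/CC[C@H](OC)[C@@H](OC(N)=O)/C(C)=C/[C@H](C)[C@H]1O`: 8910 nM

In a functional assay on HCT-116 cells (Homo sapiens) for inhibition (on this read-out higher numbers stand for weaker inhibition of growth and lower numbers for stronger inhibition of growth), compound 1 reaches only the assay limit, > 10000 nM, as noted in the limit of > 10000 nM in this assay, at which 1 of the 3 values shown sits. Among the two numbers, compound 3 stands highest with 8910 nM, while compound 2 gives 610 nM, a gap beyond the scatter. Compound 4 `COc1c(O)cc2cc1C[C@@H](C)C[C@H](OC)[C@H](O)[C@@H](C)/C=C(\C)[C@H](OC(N)=O)[C@@H](OC)CC/C=C(\C)C(=O)N2` has not been measured yet. It differs from compound 3 by methyl in place of hydrogen on an oxygen on an aromatic ring, so that the hydroxy becomes a methoxy. Since compound 2, which also carries a methoxy on the aromatic ring, gives 610 nM, a step toward stronger inhibition, a 3.0-fold lower number from compound 3 to compound 4 (0.47 log units; beyond the scatter), is expected. Compound 4 is estimated at 3000 nM, within 800 nM to 10000 nM.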

Compound 4, concentration for 50% growth inhibition: 500 nM
For compound 4 the middle estimate is 6.0-fold (0.78 log units) above the measured one; the whole stated range lies above it.
By their numbers in this assay, from the lowest: compounds 4 and 2 (each within the scatter of the next); then compound 3. At a limit, above all of these: compound 1.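

Turning the hydroxy into a methoxy on this oxygen on an aromatic ring produces a large gain in this assay: an 18-fold lower number from compound 3 to compound 4 (1.25 log units; beyond the scatter). Hydrogen in place of acetyl on the other oxygen on the ring then makes no difference that can be told apart, with a 1.2-fold lower number from compound 2 to compound 4 (0.09 log units; within the scatter), so the stronger inhibition in these compounds holds with either group there. Nothing at hand accounts for the size of the methyl step.

From the compounds shown here alone, whether an ethyl or a longer chain on this oxygen, or an amine in place of the methoxy, would keep this inhibition remains open.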